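The compounds below may be only part of what the source reports. "The series", "measured", "known", "first", "only" and "open" are said of these compounds alone.

The series shares the core seen in compound 1 `CCOC(=O)C(=Cc1c(-c2ccccc2)[nH]c2ccccc12)C(=O)OCC` and compound 2 `CC(=O)/C(=C\c1c(-c2ccccc2)[nH]c2ccccc12)S(=O)(=O)c1ccccc1`. In a functional assay on RXF 393 cells (Homo sapiens) for inhibition, read by sulforhodamine B assay, with a stated time of 48 h (a lower number here means a stronger inhibitor of growth, a higher number a weaker inhibitor of growth), compound 1 gives 3700 nM, and in this assay compound 2 gives 1300 nM, the lower of the two numbers, with the gap to compound 1 beyond the scatter. Compound 3 `O=C(/C(=C\c1c(-c2ccccc2)[nH]c2ccccc12)S(=O)(=O)c1ccccc1)c1ccccc1` has not yet been measured in this assay. It differs from compound 2 in one place: phenyl in place of methyl on a carbonyl carbon. Among the measured compounds shown here, no measured pair shows this change, so its size cannot be read from the numbers at hand; a step of modest size in either direction, or none beyond the scatter, is expected. Compound 3 is expected to give 1000 nM in this assay, with a range from 300 nM to 4000 nM. The expected step is a 1.3-fold lower number from compound 2 to compound 3 (0.11 log units; within the scatter), kept near the scatter since nothing in the series argues for more.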

Compound 3, concentration for 50% growth inhibition: 97100 nM
For compound 3 the middle estimate is 97-fold (1.99 log units) below the measured one, outside the stated range (above it).
By their numbers in this assay, from the lowest: compound 2; then compound 1; then compound 3.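

In this assay, this position on the carbonyl carbon is highly sensitive to the change from acetyl to benzoyl, which gives a 75-fold higher number from compound 2 to compound 3 (1.87 log units; beyond the scatter). This single replacement of methyl by phenyl moves the number far beyond the scatter, so the group on this carbonyl carbon strongly affects the read-out within the shared core. Nothing available bears on the reason for a step of this size.

On these data alone, it remains open whether an ethyl or cyclopropyl group on this carbonyl carbon would stay close to compound 2 or move towards compound 3, and whether a substituted phenyl, such as 4-hydroxyphenyl, would recover any of the loss. As far as these compounds go, how an amine at the same place would read in this assay is also open, as is whether the step would carry over to compounds of the shared core with other groups elsewhere.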